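A few compounds are considered here, and "the series" means these few. Any claim that something is new, unique, unknown or untested is made for them only; others in the source may bear on it.

Of the compounds shown here, three sharing one core have been measured in a functional assay on DU-145 cells (Homo sapiens) for inhibition, read by MTT assay, with a stated time of 48 h; a lower number here means a stronger inhibitor, a higher number a weaker inhibitor. Compound 1 `COc1ccc(-c2nc3ccccn3c2Sc2ccccc2)cc1` gives 76800 nM, compound 2 `CSc1ccc(-c2nc3ccccn3c2Sc2ccccc2)cc1` gives 52100 nM, and compound 3 `c1ccc(Sc2c(-c3cccs3)nc3ccccn23)cc1` gives 24100 nM. Compound 3 therefore has the lowest number of the three, and its gaps to both others lie beyond the scatter.

The next change leads to compound 4 `Clc1ccc(-c2nc3ccccn3c2Sc2ccccc2)cc1`, with 4-chlorophenyl in place of thiophen-2-yl on an aromatic carbon. Two measured steps made the opposite kind of exchange at this same carbon. The step of a 3.2-fold lower number from compound 1 to compound 3 (0.50 log units; beyond the scatter) put thiophen-2-yl in place of 4-methoxyphenyl, and the step of a 2.2-fold lower number from compound 2 to compound 3 (0.33 log units; beyond the scatter) put it in place of 4-(methylsulfanyl)phenyl. Both were modest. The step of a 1.5-fold lower number from compound 1 to compound 2 (0.17 log units; within the scatter), which altered only the group carried on that phenyl ring, stayed within the scatter. Going by the values given here, no compound with 4-chlorophenyl has been measured yet, so the comparison rests on these two other phenyl groups. Returning from thiophen-2-yl to a substituted phenyl is thus expected to give a modest move to a higher number in this assay. The expected size is a 2.0-fold higher number from compound 3 to compound 4 (0.30 log units; within the scatter). For compound 4 the estimated value is 48000 nM, with an expected range from 22000 nM to 100000 nM.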

Compound 4, half-maximal inhibitory concentration: 30700 nM
Beside the measured number, compound 4's estimate is 1.6-fold (0.19 log units) above it; low and high end bracket the measured number.
By their numbers in this assay, from the lowest: compounds 3, 4, 2 and 1 (each within the scatter of the next, the first and the last beyond it).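

In this assay, the exchange of thiophen-2-yl for 4-chlorophenyl on this aromatic carbon gives a 1.3-fold higher number from compound 3 to compound 4 (0.11 log units; within the scatter), so a phenyl ring at this position does not by itself set a compound apart from the thiophen-2-yl compound, although the 4-methoxyphenyl and 4-(methylsulfanyl)phenyl groups had both done so. The group carried on the phenyl ring now makes a readable difference, as chloro in place of methoxy gives a 2.5-fold lower number from compound 1 to compound 4 (0.40 log units; beyond the scatter), a modest step of a kind the exchange of methoxy for methylsulfanyl had not shown. Chloro in place of methylsulfanyl gives a 1.7-fold lower number from compound 2 to compound 4 (0.23 log units; within the scatter), so compound 4 cannot be separated from compound 2 or compound 3, even though those two lie beyond the scatter of each other.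

No measurement shown here accounts for these differences. The compounds shown leave open whether an amine or a carboxylic acid on the phenyl ring, or another group in place of the phenylsulfanyl group shared by all four, would shift the number in this assay beyond the scatter of compound 3.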